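Alkoxy side chains on the shared core: toward compound 4

A few compounds are considered here, and "the series" means these few. Any claim that something is new, unique, unknown or untested is made for them only; others in the source may bear on it.

Measured so far in an assay on cells with melanin-concentrating hormone receptor 1 (Homo sapiens) as the target, read by radioligand binding; on this read-out lower numbers stand for stronger inhibition and higher numbers for weaker inhibition:
compound 1 `COCC(C)Oc1cccc2ccc(N)nc12` — compound 1 gives 606 nM
compound 2 `CCOCCOc1cccc2ccc(N)nc12` — compound 2 gives > 2000 nM, a limit of the assay
compound 3 `CC#CCCOc1cccc2ccc(N)nc12` — compound 3 gives > 2000 nM, a limit of the assay

Compound 3 therefore stands at a limit only, with no number of its own; two of the three values sit at that limit (the limit of > 2000 nM in this assay, at which 2 of the 3 values shown sit).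

Compound 4 `CCOCC(C)Oc1cccc2ccc(N)nc12` is not yet measured. It differs from compound 3 by a group of 6 heavy atoms (5 carbon, 1 oxygen; no ring) in place of a group of 5 heavy atoms (5 carbon; no ring), on an oxygen on an aromatic ring. Its side chain combines features of compound 1 and compound 2, so those two compounds are the reference points.

Going by the values given here, two measured steps bear on the change: an at least 3.3-fold higher number from compound 1 to compound 3 (0.51 log units; beyond the scatter) and an at least 3.3-fold higher number from compound 1 to compound 2 (0.51 log units; beyond the scatter). The third, a step that the two limits leave unreadable from compound 2 to compound 3, gives no size. Among the compounds with values here, compound 1 is the only compound with a number, and compound 4 resembles it more than compound 3 does; the ethoxy of compound 2, however, went with a limit.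

For compound 4 a downward step from the limit is expected, an at least 2.0-fold lower number from compound 3 to compound 4 (0.30 log units; that floor lies within the scatter). For compound 4 the estimate is 1000 nM, between 300 nM and 3000 nM.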

Compound 4, half-maximal inhibitory concentration: 1070 nM
Compound 4: middle estimate off by 1.1-fold (0.03 log units), on the low side; measured number inside the range.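

In this assay, methyl in place of hydrogen on a saturated chain carbon bound to an oxygen on an aromatic ring separates compound 4 from compound 2, so the ethoxy group alone does not hold a side chain at the limit: the change gives an at least 1.8-fold lower number from compound 2 to compound 4 (0.27 log units; that floor lies within the scatter). The change from the pent-3-yn-1-yl chain gives an at least 1.8-fold lower number from compound 3 to compound 4 (0.27 log units; that floor lies within the scatter), and neither of these floors clears the scatter. Methyl in place of hydrogen on a saturated chain carbon bound to an oxygen on a saturated carbon gives a 1.8-fold higher number from compound 1 to compound 4 (0.25 log units; within the scatter), so this change does not separate the two compounds.

Going by these compounds, compound 2 and compound 3 both remain at a limit, and the step between them cannot be read: the limit of > 2000 nM in this assay, at which 2 of the 4 values shown sit. Whether a hydroxyl, an amine or a longer chain in place of the ethoxy of compound 4 would give a separable number remains open.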